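Ring Substituent Swap in a Cholesterol Acyltransferase Inhibitor Series

The compounds below may be only part of what the source reports. "The series", "measured", "known", "first", "only" and "open" are said of these compounds alone.

Three measured compounds share one core and differ only in the group on the aromatic ring that sits on the saturated five-membered ring. In an assay on microsomes for inhibition of acyl-CoA:cholesterol acyltransferase (Oryctolagus cuniculus) (a higher number here means a weaker inhibitor, a lower number a stronger inhibitor), compound 1 `Cc1ccc(C2(CNC(=O)Nc3c(C(C)C)cccc3C(C)C)CCCC2)cc1` gives 25 nM. Compound 2 `COc1ccc(C2(CNC(=O)Nc3c(C(C)C)cccc3C(C)C)CCCC2)cc1` gives 31 nM, and compound 3 `CC(C)c1cccc(C(C)C)c1NC(=O)NCC1(c2ccc(NCCO)cc2)CCCC1` gives 25 nM. Compound 2 shows the highest of the three numbers, yet the step of a 1.2-fold higher number from compound 1 to compound 2 (0.09 log units; within the scatter) and the step of a 1.2-fold lower number from compound 2 to compound 3 (0.09 log units; within the scatter) both lie within the scatter, as does no change at the digits printed from compound 1 to compound 3 (within the scatter), so the three cannot be put in order.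

Compound 4 `Cc1ccc(C2(CNC(=O)Nc3c(C(C)C)cccc3C(C)C)CCCC2)c(C)c1` has not yet been measured. It differs from compound 2 in this way: 2,4-dimethylphenyl in place of 4-methoxyphenyl on a saturated ring carbon. Within the data shown here, the change undoes the exchange seen in a 1.2-fold higher number from compound 1 to compound 2 (0.09 log units; within the scatter) and at the same time adds a second methyl to the same aromatic ring; no measured pair speaks to that added methyl. Every exchange measured so far on this ring has stayed within the scatter, and the same is expected here. Compound 4 is therefore expected to give about 28 nM, with a likely range from 12 nM to 65 nM. The expected step is a 1.1-fold lower number from compound 2 to compound 4 (0.04 log units; within the scatter), within the scatter.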

Compound 4, half-maximal inhibitory concentration: 50 nM
Beside the measured number, compound 4's estimate is 1.8-fold (0.25 log units) below it; the measured number falls inside the stated range.
By their numbers in this assay, from the lowest: compounds 1, 3, 2 and 4 (each within the scatter of the next).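

Among these compounds, with compound 4, the aromatic ring carries an added methyl for the first time, and in this assay this single exchange of methyl in place of hydrogen on an aromatic carbon appears as a 2.0-fold higher number from compound 1 to compound 4 (0.30 log units; within the scatter). Replacing the whole group on the saturated ring carbon gives a 1.6-fold higher number from compound 2 to compound 4 (0.21 log units; within the scatter) and a 2.0-fold higher number from compound 3 to compound 4 (0.30 log units; within the scatter), so neither 2,4-dimethylphenyl in place of 4-methoxyphenyl, which removes the only hydrogen-bond acceptor in that group, nor the exchange for 4-((2-hydroxyethyl)amino)phenyl separates compound 4 from the others beyond the scatter. Nothing available explains how these numbers arise or bears on this added methyl.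

The compounds shown leave open whether a different group at the carbon that takes the added methyl, such as a chlorine, an amine or a carboxylic acid, would produce a step beyond the scatter. They also leave open whether a longer chain on that carbon, or a second added methyl on the same aromatic ring, would stay within the scatter as every exchange on this ring has so far.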